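From Benzoxazolylsulfanyl to Phenylpiperazinyl on the Acetamide Chain

The compounds below may be only part of what the source reports. "The series", "measured", "known", "first", "only" and "open" are said of these compounds alone.

Three compounds share one core and differ only in the group on a saturated chain carbon bound to a carbonyl carbon. Compound 1 `Cn1c(-c2ccc(NC(=O)CCl)cc2)nc(-c2ccccc2)c1-c1ccccc1` gives 28.7 ug/mL in a functional assay on HT-29 cells (Homo sapiens) for cytotoxicity, read by MTT assay, with a stated time of 24 h; on this read-out lower numbers stand for stronger inhibition and higher numbers for weaker inhibition. Compound 2 `Cn1c(-c2ccc(NC(=O)CSc3nc4ccccc4o3)cc2)nc(-c2ccccc2)c1-c1ccccc1` gives 11 ug/mL, the lowest of the three numbers, and compound 3 `Cn1c(-c2ccc(NC(=O)CSc3nc4ccccc4s3)cc2)nc(-c2ccccc2)c1-c1ccccc1` gives 18 ug/mL. The steps are a 2.6-fold lower number from compound 1 to compound 2 (0.42 log units; beyond the scatter), a 1.6-fold lower number from compound 1 to compound 3 (0.20 log units; within the scatter) and a 1.6-fold higher number from compound 2 to compound 3 (0.21 log units; within the scatter). Compound 4 `Cn1c(-c2ccc(NC(=O)CN3CCN(c4ccccc4)CC3)cc2)nc(-c2ccccc2)c1-c1ccccc1` is the next member: 4-phenylpiperazin-1-yl in place of (1,3-benzoxazol-2-yl)sulfanyl on a saturated chain carbon bound to a carbonyl carbon. Within the data shown here, the measured steps all touch this place; only the step from chloro moved beyond the scatter, and exchanging 1,3-benzothiazol-2-yl for 1,3-benzoxazol-2-yl on a sulfur did not. Compound 4 is therefore expected to show no step beyond the scatter, a 1.3-fold higher number from compound 2 to compound 4 (0.10 log units; within the scatter). Compound 4 is estimated at 14 ug/mL, with a range from 7 ug/mL to 30 ug/mL.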

Compound 4, half-maximal inhibitory concentration: 8.6 ug/mL
For compound 4 the middle estimate is 1.6-fold (0.21 log units) above the measured one, within the range that was stated.
By their numbers in this assay, from the lowest: compounds 4, 2, 3 and 1 (each within the scatter of the next, the first and the last beyond it).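

In this assay, placing 4-phenylpiperazin-1-yl on the saturated chain carbon bound to a carbonyl carbon gives a 1.3-fold lower number from compound 2 to compound 4 (0.11 log units; within the scatter), so this position also accepts a non-aromatic ring with 2 hetero atoms and no sulfur link. The same group gives a 2.1-fold lower number from compound 3 to compound 4 (0.32 log units; beyond the scatter) and a 3.3-fold lower number from compound 1 to compound 4 (0.52 log units; beyond the scatter), so the lower number against chloro does not depend on a sulfur link. Nothing available explains these steps.

Open, from the compounds shown here alone, is how a piperazine without the phenyl ring, a morpholine or a dimethylamino group would read at this place. Also open, going by these compounds, is the effect of a longer chain carrying the 4-phenylpiperazin-1-yl.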